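Hydroxy for Fluoro in a Two-Compound Series

The compounds below may be only part of what the source reports. "The series", "measured", "known", "first", "only" and "open" are said of these compounds alone.

In a functional assay on MCF7 cells (Homo sapiens) for inhibition, read by sulforhodamine B assay, with a stated time of 48 h (on this read-out higher numbers stand for weaker inhibition of growth and lower numbers for stronger inhibition of growth), compound 1 `CC1(/C=C/c2ccc(C(F)(F)F)cc2)C=CC(=O)O1` gives 20400 nM and compound 2 `CC1(/C=C/c2ccc(F)cc2)C=CC(=O)O1` gives 38500 nM as its own reading. Among the measured compounds shown here, the step on these two numbers is a 1.9-fold higher number from compound 1 to compound 2 (0.28 log units; within the scatter) and it stays within the scatter, which leaves compound 2 level with its only measured neighbour.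

Compound 3 `CC1(/C=C/c2ccc(O)cc2)C=CC(=O)O1` has not yet been measured. It differs from compound 2 by hydroxy in place of fluoro on an aromatic carbon and by nothing else. For the measured compounds named here, no measured compound here carries hydroxy, so the evidence for this change is thin. Going by the values given here, only one measured step bears on it, a replacement at the same aromatic carbon. That step of a 1.9-fold higher number from compound 1 to compound 2 (0.28 log units; within the scatter) did not go beyond the scatter, so for compound 3 no step beyond the scatter is expected in this assay on this evidence. The estimated step is a 1.3-fold lower number from compound 2 to compound 3 (0.11 log units; within the scatter) and no firm direction is expected from it. For compound 3 the estimate is 30000 nM with 12000 nM to 75000 nM as the expected range.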

Compound 3, concentration for total growth inhibition: 69100 nM
Beside the measured number, compound 3's estimate is 2.3-fold (0.36 log units) below it; the range from low to high includes it.
By their numbers in this assay, from the lowest: compounds 1, 2 and 3 (each within the scatter of the next, the first and the last beyond it).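

In this assay, this aromatic carbon now carries three different groups, and hydroxy in place of fluoro gives a 1.8-fold higher number from compound 2 to compound 3 (0.25 log units; within the scatter), a step that stays within the scatter, just as the earlier replacement did. Hydroxy in place of trifluoromethyl, however, gives a 3.4-fold higher number from compound 1 to compound 3 (0.53 log units; beyond the scatter), the first step at this position to go beyond the scatter, though only modestly, and it points towards weaker inhibition of growth. The position is therefore not wholly indifferent to its substituent, as trifluoromethyl and hydroxy are separated while fluoro is separated from neither, but nothing available accounts for this difference.

Compound 3 alone carries a hydrogen-bond donor, so these compounds cannot show whether the separation from compound 1 goes with that donor or with something else that differs between hydroxy and trifluoromethyl. They also leave open how an amine, a methoxy group or a carboxylic acid on this same aromatic carbon would read, and whether any of these would stand apart from compound 1 or compound 3.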